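Swapping 4-Fluorophenyl for Benzoyl on the Sulfur Chain

The source may hold more compounds than are shown below. What is called first, only, known or untested is meant among the compounds shown, and "the series" means these compounds.

In a functional assay on HCT-116 cells (Homo sapiens) for inhibition, read by MTT assay, with a stated time of 48 h (a higher number here means a weaker inhibitor, a lower number a stronger inhibitor), compound 1 `COc1ccc(-n2c(S)nnc2-c2cc(OC)c(OC)c(OC)c2)cc1` gives > 60000 nM, which is a limit of the assay. Going by the values given here, compound 2 `COc1ccc(-n2c(SCc3ccc(F)cc3)nnc2-c2cc(OC)c(OC)c(OC)c2)cc1` gives 38700 nM, the only actual number so far. Among the compounds with values here, the one measured step, an at least 1.5-fold lower number from compound 1 to compound 2 (0.19 log units; that floor lies within the scatter), adds 4-fluorobenzyl on the sulfur, and it sets no firm size. Compound 3 `COc1ccc(-n2c(SCC(=O)c3ccccc3)nnc2-c2cc(OC)c(OC)c(OC)c2)cc1` carries benzoyl in place of 4-fluorophenyl on a saturated chain carbon bound to a sulfur. Within the data shown here, no measured step covers this exchange, so no shift beyond the scatter is expected in this assay. The expected change is a 1.0-fold lower number from compound 2 to compound 3 (0.01 log units; within the scatter). The nearby ceiling is the limit of > 60000 nM in this assay, at which 1 of the 2 values shown sits. Compound 3 is estimated at 38000 nM, within 15000 nM to 60000 nM.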

Compound 3, half-maximal inhibitory concentration: > 60000 nM
Compound 3: only a limit was reported (the forecaster's own chance of this, stated with the estimate: 30%); middle value at least 1.5-fold (0.19 log units) from the limit.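

Benzoyl in place of 4-fluorophenyl on a saturated chain carbon bound to a sulfur gives an at least 1.5-fold higher number from compound 2 to compound 3 (0.19 log units; that floor lies within the scatter), so this change shows no gain, and its size remains only a floor. The step from compound 1 to compound 3 cannot be read, since both values are limits. Compound 3 gives only a limit, not a number: the limit of > 60000 nM in this assay, at which 2 of the 3 values shown sit.

The compounds shown leave the true size of the exchange open. They also leave open whether an amine or a carboxylic acid on that chain carbon would give a lower number than compound 2.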